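This account rests on a few compounds, and the source may have more. Where it says the series, first, only, none or still open, it means among the compounds named here.

In a functional assay on SMMC-7721 cells (Homo sapiens) for antiproliferative activity, read by MTT assay, with a stated time of 48 h (a lower number here means a stronger inhibitor, a higher number a weaker inhibitor), compound 1 `Cn1cc(C2=C(c3nn(CCn4ccnc4)c4ncccc34)C(=O)N(c3ccccc3)C2=O)c2ccccc21` gives > 100000 nM, which is a limit of the assay and not a number. Going by the values given here, compound 2 `CN(C)CCCn1nc(C2=C(c3cn(C)c4ccccc34)C(=O)N(c3ccccc3)C2=O)c2cccnc21` gives 31200 nM, the only true number so far. Compound 3 `Cn1cc(C2=C(c3nn(CCCn4cccc4)c4ncccc34)C(=O)N(c3ccccc3)C2=O)c2ccccc21` is not yet measured. Its difference from compound 2 is 1H-pyrrol-1-yl in place of dimethylamino on a saturated chain carbon, three bonds along the chain from an aromatic nitrogen, with 1H-pyrrol-1-yl in place of dimethylamino on a saturated chain carbon, three bonds along the chain from an aromatic nitrogen. Among the compounds with values here, one measured step bears on this change: an at least 3.2-fold lower number from compound 1 to compound 2 (0.50 log units; beyond the scatter), which brought in the dimethylamino end and removed a ring at the end of the chain. Compound 3 puts a ring back at the chain end, so the reverse of an at least 3.2-fold lower number from compound 1 to compound 2 (0.50 log units; beyond the scatter) is expected, though the two rings differ and that step is open-ended. The expected change is a 1.9-fold higher number from compound 2 to compound 3 (0.28 log units; within the scatter), a modest weakening. Compound 3 is estimated at 60000 nM, with an expected range from 20000 nM to 130000 nM.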

Compound 3, half-maximal inhibitory concentration: > 100000 nM
Compound 3: only a limit was reported; the forecaster's own chance of this, stated with the estimate: 35%; at least 1.6-fold (0.22 log units) between middle value and limit.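

With the 3-(dimethylamino)propyl chain changed to 3-(1H-pyrrol-1-yl)propyl, this assay shows an at least 3.2-fold higher number from compound 2 to compound 3 (0.50 log units; beyond the scatter), so the group at the end of this chain clearly matters. Compound 1, with 1H-imidazol-1-yl, and compound 3, with 1H-pyrrol-1-yl, both give only a limit of the assay and not a number, so the step between them cannot be read. Among these three compounds, only the dimethylamino end gives a true number, and neither ring end does: the limit of > 100000 nM in this assay, at which 2 of the 3 values shown sit.

Going by these compounds, how large the step to compound 3 really is stays unknown, since only its lower bound can be read. Also open, on these data alone, is whether another amine at the chain end, such as piperidine or morpholine, or a longer chain carrying dimethylamino, would give a lower number than compound 2.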